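This account rests on a few compounds, and the source may have more. Where it says the series, first, only, none or still open, it means among the compounds named here.

Working notes on the series: in a functional assay on A549 cells (Homo sapiens) for inhibition, read by MTT assay, with a stated time of 72 h (on this read-out lower numbers stand for stronger inhibition and higher numbers for weaker inhibition), compound 1 `C=C(Cl)C(=O)Nc1cc(Nc2nc3c(c(-c4cn(C)c5ccccc45)n2)CS(=O)(=O)CC3)c(OC)cc1N(C)CCN(C)C` gives 881 nM and compound 2 `C/C=C\C(=O)Nc1cc(Nc2nc3c(c(-c4cn(C)c5ccccc45)n2)CS(=O)(=O)CC3)c(OC)cc1N(C)CCN(C)C` gives 4260 nM on this read-out. Compound 2 therefore holds the higher of the two numbers, the weaker end of what has been measured. Among the measured compounds shown here, the single measured step of a 4.8-fold higher number from compound 1 to compound 2 (0.68 log units; beyond the scatter) is prop-1-en-1-yl in place of 1-chloroethenyl on a carbonyl carbon, and it lies beyond the scatter.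

The unmeasured compound 3 `CC/C=C\C(=O)Nc1cc(Nc2nc3c(c(-c4cn(C)c5ccccc45)n2)CS(=O)(=O)CC3)c(OC)cc1N(C)CCN(C)C` carries the change methyl in place of hydrogen on a saturated chain carbon bound to a double-bonded chain carbon on the same side chain. In words, this is methyl in place of hydrogen on a saturated chain carbon bound to a double-bonded chain carbon, turning prop-1-en-1-yl into but-1-en-1-yl. For the measured compounds named here, the step from compound 1 touches this group but swaps a different substituent, and no measured step adds a methyl at this place. Going by the values given here, only a small change is therefore expected in this assay, leaning towards a higher number, in the direction of a 4.8-fold higher number from compound 1 to compound 2 (0.68 log units; beyond the scatter) as the only guide. The expected 1.2-fold higher number from compound 2 to compound 3 (0.07 log units; within the scatter) may well not clear the scatter. For compound 3 the estimated value is 5000 nM with 2000 nM to 12000 nM as the working range.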

Compound 3, half-maximal inhibitory concentration: 1350 nM
Compound 3: the middle estimate sits 3.7-fold (0.57 log units) above what was measured; the measured number lies below the stated range.
By their numbers in this assay, from the lowest: compounds 1 and 3 (each within the scatter of the next); then compound 2.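

Working notes, compound 3: In this assay, methyl in place of hydrogen on a saturated chain carbon bound to a double-bonded chain carbon gives a 3.2-fold lower number from compound 2 to compound 3 (0.50 log units; beyond the scatter), so this place on the side chain responds to the change from prop-1-en-1-yl to but-1-en-1-yl, and the step runs towards stronger inhibition. The result also shows that losing 1-chloroethenyl does not by itself bring a step beyond the scatter, since a 4.8-fold higher number from compound 1 to compound 2 (0.68 log units; beyond the scatter) stands against a 1.5-fold higher number from compound 1 to compound 3 (0.19 log units; within the scatter) and only the first of these clears the scatter. The data on hand offer nothing that bears on the reason for the methyl step.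

The compounds shown leave open whether a longer chain such as pent-1-en-1-yl, a branched group such as isopropyl or an amine such as dimethylamino at this saturated chain carbon would extend the step or reverse it. With one step at this place no trend in chain length can be claimed, and every reading comes from this assay alone, so nothing is shown for any other cells.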